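Chloro Shift on the Triazole Phenyl Ring

The source may report more compounds than this note shows. Statements on the series, on what has been measured and on what is new or still open speak of the compounds shown alone.

Compound 3 `O=c1[nH]cc(S(=O)(=O)Nc2ccc(-c3cn(-c4ccc(F)cc4)nn3)cc2)c(=O)[nH]1` gives in a functional assay on OVCAR-3 cells (Homo sapiens) for antiproliferative activity, read by MTT assay, with a stated time of 24 h (on this read-out lower numbers stand for stronger inhibition and higher numbers for weaker inhibition), only a limit, > 20000 nM. Compound 1 `O=c1[nH]cc(S(=O)(=O)Nc2ccc(-c3cn(-c4ccccc4)nn3)cc2)c(=O)[nH]1` gives 18000 nM, and compound 2 `O=c1[nH]cc(S(=O)(=O)Nc2ccc(-c3cn(-c4ccccc4F)nn3)cc2)c(=O)[nH]1` gives 8030 nM; the measured steps were a 2.2-fold lower number from compound 1 to compound 2 (0.35 log units; beyond the scatter) and an at least 1.1-fold higher number from compound 1 to compound 3 (0.04 log units; that floor lies within the scatter). Compound 3 thus sits at the upper boundary of the numbers shown, the limit (the limit of > 20000 nM in this assay, at which 1 of the 3 values shown sits). Compound 4 `O=c1[nH]cc(S(=O)(=O)Nc2ccc(-c3cn(-c4cccc(Cl)c4)nn3)cc2)c(=O)[nH]1` differs from compound 3 by 3-chlorophenyl in place of 4-fluorophenyl on an aromatic nitrogen. Among the compounds with values here, the step of an at least 2.4-fold higher number from compound 2 to compound 3 (0.39 log units; beyond the scatter) is the only one that moves the group on this ring, and no measured step tests a chloro group at all. Compound 4 is therefore expected close to where compound 3 stands, at about 15000 nM with a range from 6000 nM to 40000 nM, an estimated step of an at least 1.3-fold lower number from compound 3 to compound 4 (0.12 log units; that floor lies within the scatter).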

Compound 4, half-maximal inhibitory concentration: 2750 nM
Compound 4: the middle estimate sits 5.5-fold (0.74 log units) above what was measured; measured number outside the range, below it.
By their numbers in this assay, from the lowest: compound 4; then compound 2; then compound 1. At a limit, above all of these: compound 3.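

In this assay, the 3-chlorophenyl group gives the lowest number shown, with steps of a 6.5-fold lower number from compound 1 to compound 4 (0.82 log units; beyond the scatter), a 2.9-fold lower number from compound 2 to compound 4 (0.47 log units; beyond the scatter) and an at least 7.2-fold lower number from compound 3 to compound 4 (0.86 log units; beyond the scatter). A chloro group on this phenyl ring thus goes further than either fluoro compound. Compound 3 stands only at a limit: the limit of > 20000 nM in this assay, at which 1 of the 4 values shown sits.

Halogen and ring position change together here, so the compounds shown do not separate the two. Going by these compounds, whether 3-fluorophenyl, 4-chlorophenyl, 3-methoxyphenyl or 3-carboxyphenyl on this aromatic nitrogen would match compound 4 stays open.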